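The source may report more compounds than this note shows. Statements on the series, on what has been measured and on what is new or still open speak of the compounds shown alone.

Compound 1 `COc1ccc(C2=NNC(c3c(Cl)cccc3Cl)C2)cc1` and compound 2 `COc1ccc(C2=NN(C(=O)CBr)C(c3c(Cl)cccc3Cl)C2)cc1OC` were both tested in a functional assay on the whole organism (strain albino) for inhibition, with Rattus norvegicus as the target, read by paw edema, with stated times of 30 min and 1 h, at a dose of 100 mg/kg by the oral route; a lower number here means less inhibition, a higher number more inhibition at the dose given (going by the name of the read-out). In this assay compound 1 gives 54%, and compound 2 gives 48%. Compound 2 has the lowest of the two numbers shown, but the gap to compound 1 lies within the scatter, so the two cannot be told apart. Compound 3 `COc1ccc(C2=NN(C(=O)CBr)C(c3c(Cl)cccc3Cl)C2)cc1` differs from compound 2 in one place: hydrogen in place of methoxy on an aromatic carbon. Among the measured compounds shown here, no measured pair differs in a single group, so this step has no direct precedent. The step of a number 2 percentage points higher from compound 2 to compound 3 (within the scatter) is expected to stay within the scatter, in no particular direction. Compound 3 is estimated to give 50%, within a range from 35% to 65%.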

Compound 3, a percentage reported as inhibition, in the whole organism at one dose (the size of the read-out at that dose, not a potency): 43%
Compound 3: middle estimate off by 7 percentage points, on the high side; the range from low to high includes it.
By their numbers in this assay, from the lowest: compounds 3, 2 and 1 (each within the scatter of the next, the first and the last beyond it).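

Swapping methoxy for hydrogen on this aromatic carbon gives a number 5 percentage points lower from compound 2 to compound 3 (within the scatter) in this assay, so this methoxy group shows no clear effect on the read-out at this dose. Placing (bromomethyl)carbonyl instead of hydrogen on the amine nitrogen in a ring gives a number 11 percentage points lower from compound 1 to compound 3 (beyond the scatter), a first modest change beyond the scatter and a sign that this nitrogen may matter more. Nothing available explains either step.

On these data alone, whether a simple acetyl group or a longer chain ending in an amine on that nitrogen would shift the number remains open. So does the effect of fluorine or a hydroxyl group on the aromatic carbon.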